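Moving the Acid Group on the Carboxybenzyl Arm

The compounds below may be only part of what the source reports. "The series", "measured", "known", "first", "only" and "open" are said of these compounds alone.

Compound 1 `CN(Cc1cccc(C(=O)O)c1)c1ccc(OCc2c(-c3c(Cl)cccc3Cl)noc2C2CC2)nc1C(F)(F)F` and compound 2 `CN(Cc1ccc(C(=O)O)cc1)c1ccc(OCc2c(-c3c(Cl)cccc3Cl)noc2C2CC2)nc1C(F)(F)F` share one core and differ only in where the acid sits on the carboxybenzyl arm. In a functional assay on HEK293 cells for agonist activity at Bile acid receptor (Homo sapiens) (a higher number here means a larger maximal response, a lower number a smaller maximal response), compound 2 reaches 81%, and compound 1 reaches 79%. The change between them is 3-carboxyphenyl in place of 4-carboxyphenyl on a saturated chain carbon bound to a nitrogen on an aromatic ring, and it made a number 2 percentage points lower from compound 2 to compound 1 (within the scatter). Compound 3 `CC(C)c1onc(-c2c(Cl)cccc2Cl)c1COc1cnc(N(C)Cc2ccc(C(=O)O)cc2)c(Cl)c1` carries the 4-carboxyphenyl group on a different core; how that core differs from the core of compound 2 is not broken down here. In this assay compound 3 gives 70%. Compound 4 `CC(C)c1onc(-c2c(Cl)cccc2Cl)c1COc1cnc(N(C)Cc2cccc(C(=O)O)c2)c(Cl)c1` has not yet been measured. It differs from compound 3 by 3-carboxyphenyl in place of 4-carboxyphenyl on a saturated chain carbon bound to a nitrogen on an aromatic ring, at the same place as in the earlier pair, so it is the same change applied to the other core. Resting on that one earlier step, a number 2 percentage points lower from compound 2 to compound 1 (within the scatter), the expected step for compound 4 is a number 2 percentage points lower from compound 3 to compound 4 (within the scatter). Compound 4 is therefore estimated to reach 68% in this assay, with a likely range from 58% to 78%, an expectation that rests on a single prior example.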

Compound 4, largest response reached (reported as efficacy), in percent of the reference or control that the assay uses: 42%
The estimate for compound 4 lay 26 percentage points above the measured number; the measured number lies below the stated range.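

In this assay, putting 3-carboxyphenyl in place of 4-carboxyphenyl gave a number 28 percentage points lower from compound 3 to compound 4 (beyond the scatter). Set beside the earlier pair, this shows that the same change did not carry over at the same size from one core to the other: the same change on two cores in this assay, a number 2 percentage points lower (within the scatter) from compound 2 to compound 1 and a number 28 percentage points lower (beyond the scatter) from compound 3 to compound 4, 26 percentage points apart, beyond the scatter of two such steps The result therefore warns against reading a step measured on one core as a fixed value for the change, but with only one pair on each core it does not show which part of the cores is responsible, why the steps differ, or what size of step a third core would give.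

The two cores differ in more than one place, so the compounds shown leave open whether a single core change would be enough to turn the small step into the large one. They also leave open whether a tetrazole in place of the carboxylic acid, or a longer chain carrying the acid, would depend on the core in the same way.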